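From 3,4-dichlorophenyl to 3,4-dimethylphenyl

The source may report more compounds than this note shows. Statements on the series, on what has been measured and on what is new or still open speak of the compounds shown alone.

In a functional assay on HL-60 cells (Homo sapiens) for inhibition, read by MTT assay, with a stated time of 72 h (on this read-out higher numbers stand for weaker inhibition and lower numbers for stronger inhibition), compound 1 `CCOc1cccc(N2CCN(C(=O)c3oc(C)nc3-c3ccccc3)CC2)c1` gives 151 nM, compound 2 `Cc1nc(-c2ccccc2)c(C(=O)N2CCN(c3cc(Cl)cc(Cl)c3)CC2)o1` gives 41.8 nM and compound 3 `Cc1nc(-c2ccccc2)c(C(=O)N2CCN(c3ccc(Cl)c(Cl)c3)CC2)o1` gives 124 nM. Compound 3 thus sits level with one neighbour, a 1.2-fold lower number from compound 1 to compound 3 (0.09 log units; within the scatter), and apart from the other, a 3.0-fold higher number from compound 2 to compound 3 (0.47 log units; beyond the scatter). Compound 4 `Cc1nc(-c2ccccc2)c(C(=O)N2CCN(c3ccc(C)c(C)c3)CC2)o1` carries 3,4-dimethylphenyl in place of 3,4-dichlorophenyl on an amine nitrogen in a ring. Among the compounds with values here, no measured step makes this exact exchange. The nearest evidence is the other changes at this place, and the largest of them is modest, a 3.6-fold lower number from compound 1 to compound 2 (0.56 log units; beyond the scatter). The expected result is no change beyond the scatter, a 1.1-fold higher number from compound 3 to compound 4 (0.04 log units; within the scatter). Compound 4 is estimated at 135 nM, with an expected range from 55 nM to 330 nM.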

Compound 4, half-maximal inhibitory concentration: 43 nM
Compound 4: the middle estimate sits 3.1-fold (0.50 log units) above what was measured; measured number outside the range, below it.
By their numbers in this assay, from the lowest: compounds 2 and 4 (each within the scatter of the next); then compounds 3 and 1 (each within the scatter of the next).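

In this assay, 3,4-dimethylphenyl does not read the same as 3,4-dichlorophenyl (a 2.9-fold lower number from compound 3 to compound 4 (0.46 log units; beyond the scatter)), so the exchange of the two chlorines for two methyl groups matters at this place on the ring nitrogen. The new group stands level with 3,5-dichlorophenyl (a 1.0-fold higher number from compound 2 to compound 4 (0.01 log units; within the scatter)) and apart from 3-ethoxyphenyl (a 3.5-fold lower number from compound 1 to compound 4 (0.55 log units; beyond the scatter)), so among these compounds a low number does not require chlorine. Nothing available explains these differences. The compounds shown leave open how an amine or a carboxylic acid on this phenyl ring would read.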